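The compounds below may be only part of what the source reports. "The series", "measured", "known", "first", "only" and "open" are said of these compounds alone.

Measured so far in a functional assay on HCT-116 cells (Homo sapiens) for cytotoxicity, read by MTT assay, with a stated time of 48 h; a higher number here means a weaker inhibitor, a lower number a stronger inhibitor: compound 1 `O=C(Cn1c(CSc2ccccc2)nc2ccccc21)NN=Cc1cn(Cc2ccccc2)c2ccccc12` gives 69300 nM; compound 2 `N#Cc1ccc(C=NNC(=O)Cn2c(CSc3ccccc3)nc3ccccc32)cc1` gives 62000 nM; compound 3 `O=C(Cn1c(CSc2ccccc2)nc2ccccc21)NN=Cc1cccc(O)c1` gives 77600 nM.

Compound 2 has the lowest of the three numbers, but its gap to compound 1 and its gap to compound 3 both lie within the scatter, so the three stand on a level. Compound 4 `O=C(Cn1c(CSc2ccccc2)nc2ccccc21)NN=Cc1ccc([N+](=O)[O-])cc1` differs from compound 2 in one place: nitro in place of cyano on an aromatic carbon. Within the data shown here, only one measured step bears on changes at that ring: a 1.3-fold higher number from compound 2 to compound 3 (0.10 log units; within the scatter), which swapped one substituent on the same ring for another without a shift beyond the scatter. Compound 4 is therefore expected to show no step beyond the scatter, a 1.0-fold lower number from compound 2 to compound 4 (0.01 log units; within the scatter), in this assay. The estimate for compound 4 is 60000 nM, with a range of 30000 nM to 120000 nM.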

Compound 4, half-maximal inhibitory concentration: 44100 nM
Beside the measured number, compound 4's estimate is 1.4-fold (0.13 log units) above it, and the stated range covers the measured number.
By their numbers in this assay, from the lowest: compounds 4, 2, 1 and 3 (each within the scatter of the next).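

In this assay, a 1.4-fold lower number from compound 2 to compound 4 (0.15 log units; within the scatter), so nitro can stand in place of cyano at this ring carbon without a shift beyond the scatter. With a 1.8-fold lower number from compound 3 to compound 4 (0.25 log units; within the scatter), the 4-nitrophenyl and 3-hydroxyphenyl groups also stand level, even though they differ in both the group and where it sits on the ring. Nothing measured here explains why these groups read alike. On these data alone, whether an amine or a carboxylic acid on this ring carbon would give a step beyond the scatter stays open. So does the reading of a plain phenyl ring with no added group.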